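Swapping 4-aminophenyl for 2-fluorophenyl under a cytotoxicity limit

The compounds below may be only part of what the source reports. "The series", "measured", "known", "first", "only" and "open" are said of these compounds alone.

Of the compounds shown here, three built on one shared core have been measured in an ADME assay on HEK293 cells (Homo sapiens) for cytotoxicity, with a stated time of 72 h (on this read-out higher numbers stand for an effect only at larger amounts of compound and lower numbers for an effect already at smaller amounts), so far, and none of them gives a number. Compound 1 `Cc1cc(NC(=O)Nc2ccccc2OC(F)(F)F)c2ccccc2n1` gives > 25000 nM which is a limit of the assay and not a number. Compound 2 `Cc1cc(NC(=O)Nc2ccc(O)cc2)c2ccccc2n1` gives > 25000 nM which is likewise a limit. Compound 3 `Cc1cc(NC(=O)Nc2ccc(N)cc2)c2ccccc2n1` gives > 25000 nM which is again only a limit, and that is all that can be said of where it stands. The evidence so far amounts to the limit of > 25000 nM in this assay, at which 3 of the 3 values shown sit, and nothing finer.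

Compound 4 `Cc1cc(NC(=O)Nc2ccccc2F)c2ccccc2n1` departs from compound 3 as follows: 2-fluorophenyl in place of 4-aminophenyl on an amide-type nitrogen with 2-fluorophenyl in place of 4-aminophenyl on an amide-type nitrogen. Within the data shown here, the only measured comparison at a single place is a step that the two limits leave unreadable from compound 2 to compound 3 for amino in place of hydroxy on an aromatic carbon, so it supplies no size to carry over. Compounds 1, 2 and 3 carry different groups on that nitrogen, and all three remain limits. No step beyond the usual scatter is therefore expected, in either direction. What is expected is a step that the limit leaves unreadable from compound 3 to compound 4 and it rests on limits only. The estimate for compound 4 is 30000 nM with an expected range from 15000 nM to 60000 nM in this assay and a report of only a limit is the likeliest result.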

Compound 4, half-maximal effective concentration: > 25000 nM
Compound 4: no number, only a limit; the forecaster's own chance of this, stated with the estimate: 85%; the middle value is on the limit's open side.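

In this assay compound 4 gives > 25000 nM, which is a limit of the assay and not a number. Among these compounds, no step from compound 1, compound 2 or compound 3 to compound 4 can be read. The compounds shown leave open how the groups on the amide-type nitrogen compare, as all four compounds remain limits.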